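Shortening an Alkyl Chain on a Hydroxyurea Scaffold

The source may hold more compounds than are shown below. What is called first, only, known or untested is meant among the compounds shown, and "the series" means these compounds.

Of the compounds shown here, three have been measured so far: compound 1 `CN(O)C(N)=O`, compound 3 `CCN(O)C(N)=O` and compound 2 `CCCCNC(=O)NO`. In a physicochemical assay for lipophilicity, measured as octanol-water partition, with a stated time of 72 h (a higher number here means a more lipophilic compound, a lower number a more polar compound), compound 1 gives -0.46, compound 3 gives -0.1 and compound 2 gives 0.32. Compound 2 stands highest of the three, with compound 3 its nearest neighbour and compound 1 the furthest away. How the core of compound 2 differs from the core of compound 3 is not broken down here.

Between compound 3 and compound 1 one change is made: hydrogen in place of methyl on a saturated chain carbon bound to an amide-type nitrogen In this assay that change produced a number 0.36 log units lower from compound 3 to compound 1 (beyond the scatter).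

Compound 4 `CCCNC(=O)NO` has not yet been measured in this assay. It arises from compound 2 by the same kind of change: hydrogen in place of methyl on a saturated chain carbon, three bonds along the chain from an amide-type nitrogen The two changes differ in where they sit. In compound 3 the methyl leaves a saturated chain carbon bound to an amide-type nitrogen, whereas in compound 2 it leaves a saturated chain carbon three bonds along the chain from an amide-type nitrogen. The expectation for compound 4 rests on the measured step of a number 0.36 log units lower from compound 3 to compound 1 (beyond the scatter) and on the values of compound 2 and compound 3 in this assay. The step expected is a number 0.47 log units lower from compound 2 to compound 4 (beyond the scatter), of a size similar to the earlier one. Compound 4 is therefore estimated at -0.15, most likely between -0.45 and 0.15.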

Compound 4, partition coefficient: 0.22
For compound 4 the middle estimate is 0.37 log units below the measured one, and the stated range ends below it.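

In this assay the swap of methyl for hydrogen gave a number 0.36 log units lower from compound 3 to compound 1 (beyond the scatter) on one core and a number 0.10 log units lower from compound 2 to compound 4 (within the scatter) on the other, so the size of the first step did not carry over to the second pair. The first step lies beyond the usual scatter of repeated measurements and the second lies within it, which shows that in this series a step read on one pair need not hold on another. It does not show whether the core or the place of the change decides the outcome, for the two pairs differ in both and each kind of change is seen only once, and nothing measured here offers an explanation for the difference between the two steps.

The compounds shown leave open how the numbers run along a fuller set of chains on the core of compound 4, such as ethyl or methyl, or a longer chain on the core of compound 2. They also leave open what an amine or a carboxylic acid would give in place of the methyl that leaves, and whether any such change would follow either of the two steps seen so far.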